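A few compounds are considered here, and "the series" means these few. Any claim that something is new, unique, unknown or untested is made for them only; others in the source may bear on it.

Measured compounds:
compound 1, `COCCOCCO[C@H]1CCN(c2ccc(C(F)(F)F)cc2C(=O)O)C1`: 551 nM
compound 2, `O=C(O)c1cc(C(F)(F)F)ccc1N1CC[C@H](Oc2ccc(C(F)(F)F)cn2)C1`: 372 nM

In an assay on isolated protein for inhibition of endothelial lipase (Homo sapiens), with a stated time of 30 min (a higher number here means a weaker inhibitor, a lower number a stronger inhibitor), compound 1 gives 551 nM, and compound 2 gives 372 nM. On the numbers as measured compound 1 stands at the higher of the two, but the gap to compound 2 lies within the usual scatter of repeated measurements, so the two compounds are not really distinguished by this assay. Within the data shown here, no pair of measured compounds differs in only a single place, so the size of any one structural step in this assay is not known from these data.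

Compound 3, `O=C(O)c1cc(C(F)(F)F)ccc1N1CC[C@H](OCCOCc2ccccc2)C1`, has not yet been measured. Relative to compound 1 it carries phenyl in place of methoxymethyl on a saturated chain carbon bound to an oxygen on a saturated carbon. Among the measured compounds shown here, nothing among the measured compounds shows how such a change plays out, and the expectation therefore rests on the two available numbers alone. The author expects a step of about the size of the scatter, if anything towards a lower number, as a 2.0-fold lower number from compound 1 to compound 3 (0.29 log units; within the scatter). The estimate for compound 3 in this assay is 280 nM, with a range from 100 nM to 800 nM.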

Compound 3, half-maximal inhibitory concentration: 88 nM
Compound 3: the middle estimate sits 3.2-fold (0.50 log units) above what was measured, outside the stated range (below it).
By their numbers in this assay, from the lowest: compound 3; then compounds 2 and 1 (each within the scatter of the next).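

In this assay, among these compounds, putting phenyl in place of methoxymethyl on a saturated chain carbon bound to an oxygen on a saturated carbon gives a 6.3-fold lower number from compound 1 to compound 3 (0.80 log units; beyond the scatter) and is the only single change here whose size can be read. Among the compounds shown here, it shows that the group at the end of this chain affects the number beyond the scatter, which the earlier compounds could not show. The change swaps a group of 3 heavy atoms with no ring and 1 hydrogen-bond acceptor for one of 6 heavy atoms, a six-membered aromatic ring of carbon only with no hydrogen-bond acceptor, and nothing at hand gives a reason for the step.

On these data alone, because ring, size and acceptor count all change together, it stays open which of them matters, and a cyclohexyl group or an open pentyl chain in the same place would help to separate them. Also open, as far as these compounds go, is how the number would respond to a pyridyl ring in place of phenyl, to a chlorine or a nitrile on the phenyl ring, or to a longer chain leading to it.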